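The source may hold more compounds than are shown below. What is called first, only, known or untested is meant among the compounds shown, and "the series" means these compounds.

Going by the values given here, in a functional assay on HeLa cells (Homo sapiens) for inhibition, read by MTT assay, with a stated time of 72 h (on this read-out higher numbers stand for weaker inhibition and lower numbers for stronger inhibition), three compounds built on a shared core have numbers so far. Compound 1 `COc1cc(NC(C)CCCNC(=O)Nc2ccc(Br)cc2)c2ncccc2c1` gives 20000 nM, compound 3 `COc1cc(NC(C)CCCNC(=O)NNC(=O)Nc2cc(C(F)(F)F)cc(C(F)(F)F)c2)c2ncccc2c1` gives 17000 nM, and compound 2 `COc1cc(NC(C)CCCNC(=O)Nc2cccc(O)c2)c2ncccc2c1` gives 48000 nM, the highest number of the three and so the weakest inhibition. Compound 4 `COc1cc(NC(C)CCCNC(=O)NNC(=O)Nc2ccc(O)cc2)c2ncccc2c1` has not been measured yet. The change under consideration is ((4-hydroxyphenyl)carbamoyl)amino in place of 3-hydroxyphenyl on an amide-type nitrogen. Among the compounds with values here, no measured step shows this exact swap. Within the data shown here, the one measured step, a 2.4-fold higher number from compound 1 to compound 2 (0.38 log units; beyond the scatter), is modest and beyond the scatter, and it suggests that changes at this place shift the number only moderately. Compound 3 also carries a carbamoyl amino unit at this place, and its 17000 nM lies under the number for compound 2, though its ring differs. A modest fall in the number is therefore expected, with the expected step being a 1.6-fold lower number from compound 2 to compound 4 (0.20 log units; within the scatter). For compound 4, the estimated value is 30000 nM, with an expected range from 12000 nM to 70000 nM.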

Compound 4, half-maximal inhibitory concentration: 85000 nM
Compound 4: middle estimate off by 2.8-fold (0.45 log units), on the low side; the whole stated range lies below it.
By their numbers in this assay, from the lowest: compounds 3 and 1 (each within the scatter of the next); then compounds 2 and 4 (each within the scatter of the next).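

Replacing 3-hydroxyphenyl with the larger ((4-hydroxyphenyl)carbamoyl)amino on the amide-type nitrogen gives a 1.8-fold higher number from compound 2 to compound 4 (0.25 log units; within the scatter) in this assay and so brings no readable gain in inhibition, which means compound 2 and compound 4 cannot be told apart here. The same group in place of 4-bromophenyl gives a 4.3-fold higher number from compound 1 to compound 4 (0.63 log units; beyond the scatter) as a modest loss, so both compounds with a hydroxyphenyl ring and no trifluoromethyl groups sit on the weaker side of compound 1. No measurement shown here explains these numbers.

From the compounds shown here alone, this swap adds the carbamoyl amino unit and changes the hydroxyl position together, so the share of each stays open. Going by these compounds, how an amine or a carboxylic acid on the ring would behave at this place also remains unknown.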